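The source may report more compounds than this note shows. Statements on the series, on what has been measured and on what is new or still open speak of the compounds shown alone.

Measured compounds:
- compound 1 `CC(C)(Oc1ccc(NCc2cccc(Oc3ccccc3)c2)cc1)C(=O)O`
- compound 2 `O=C(O)[C@H]1C[C@@H]1c1ccc(NCc2cccc(Oc3ccccc3)c2)cc1`
- compound 3 `CNC(=O)CCc1ccc(NCc2cccc(Oc3ccccc3)c2)cc1`

In a functional assay on CHO cells for agonist activity at Free fatty acid receptor 1 (Homo sapiens) (on this read-out lower numbers stand for an effect already at smaller amounts and higher numbers for an effect only at larger amounts of compound), compound 1 gives only a limit of the assay, < 10000 nM. Compound 2 gives 12.3 nM; 13.5 nM (2 entries) in this assay, repeated entries that show the spread of such measurements (the several entries of compound 2 in this assay, 12.3 nM; 13.5 nM (2 entries)). Among the compounds with values here, compound 3 gives 49 nM, the only single number among the three besides that pair of repeats.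

Compound 4 `CC(C)NC(=O)CCc1ccc(NCc2cccc(Oc3ccccc3)c2)cc1` differs from compound 3 by isopropyl in place of methyl on an amide-type nitrogen. Within the data shown here, the one step recorded from compound 3, a step that the limit leaves unreadable from compound 1 to compound 3, cannot be sized because of the limit of < 10000 nM in this assay, at which 1 of the 3 values shown sits; no measured step touches the amide nitrogen substituent. With nothing pointing either way, the expected step of a 1.0-fold higher number from compound 3 to compound 4 (0.01 log units; within the scatter) is none beyond the scatter. Compound 4 is therefore estimated at 50 nM, range 18 nM to 160 nM.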

Compound 4, half-maximal effective concentration: 39.8 nM
The estimate for compound 4 lay 1.3-fold (0.10 log units) above the measured number, within the range that was stated.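

Within the data shown here, on an amide-type nitrogen, isopropyl in place of methyl gives a 1.2-fold lower number from compound 3 to compound 4 (0.09 log units; within the scatter) in this assay, the only readable step at this place. Isopropyl is therefore carried here with no change beyond the scatter, which the earlier compounds could not show. The step from compound 1 to compound 4 cannot be read, since compound 1 gives only a limit: the limit of < 10000 nM in this assay, at which 1 of the 4 values shown sits.

Still open, going by these compounds, is whether a longer chain, a phenyl ring or a terminal carboxylic acid on this nitrogen would keep the value. Also open, on these data alone, is whether a second alkyl group replacing the amide hydrogen would do so.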